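The compounds below may be only part of what the source reports. "The series", "measured", "known", "first", "only" and "open" are said of these compounds alone.

compound 1 `Cn1c(=O)c(S(=O)(=O)Cc2ccc(F)cc2)cc2cnc(Nc3ccc4[nH]ccc4c3)nc21` gives 30000 nM as its value
compound 2 `COc1ccc(Nc2ncc3cc(S(=O)(=O)c4ccc(Cl)cc4)c(=O)n(C)c3n2)cc1` gives 15000 nM as its value

In a functional assay on K562 cells (Homo sapiens) for inhibition, read by trypan blue exclusion, with a stated time of 72 h (a lower number here means a stronger inhibitor, a higher number a weaker inhibitor), compound 1 gives 30000 nM as its value, which lies within the usual scatter of compound 2 with 15000 nM as its value. Compound 3 `Cn1c(=O)c(S(=O)(=O)Nc2ccc(F)cc2)cc2cnc(Nc3ccc4[nH]ccc4c3)nc21` keeps the core of compound 1 and changes one group: (4-fluorophenyl)amino in place of 4-fluorobenzyl on a sulfonyl sulfur in all. In short, (4-fluorophenyl)amino stands in place of 4-fluorobenzyl on a sulfonyl sulfur. For the measured compounds named here, no measured pair shows this change, so no shift beyond the scatter is expected. The estimated 1.5-fold lower number from compound 1 to compound 3 (0.18 log units; within the scatter) is therefore small. Compound 3 is estimated at 20000 nM with 5000 nM to 60000 nM as its range.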

Compound 3, half-maximal inhibitory concentration: 5000 nM
For compound 3 the middle estimate is 4.0-fold (0.60 log units) above the measured one; the range from low to high includes it.
By their numbers in this assay, from the lowest: compound 3; then compounds 2 and 1 (each within the scatter of the next).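

In this assay, (4-fluorophenyl)amino in place of 4-fluorobenzyl on a sulfonyl sulfur gives a 6.0-fold lower number from compound 1 to compound 3 (0.78 log units; beyond the scatter), so this position does respond to a single change of group. The two groups have the same number of heavy atoms and the same ring, but the entering group has a hydrogen-bond donor that the leaving group lacks. Nothing measured here explains the step. Still open, on these data alone, is how an N-methyl-N-(4-fluorophenyl)amino group or a morpholine on the same sulfur would read. One step also cannot show whether the change would hold on a different core.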